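The source may report more compounds than this note shows. Statements on the series, on what has been measured and on what is new or still open speak of the compounds shown alone.

Measured compounds:
- compound 1, `COc1cc(N/C=C\C(=O)c2cn(-c3ccccc3)nc2-c2ccc(F)cc2)cc(OC)c1OC`, 7770 nM in a functional assay on HT-29 cells (Homo sapiens) for antiproliferative activity, read by MTT assay, with a stated time of 48 h; on this read-out higher numbers stand for weaker inhibition and lower numbers for stronger inhibition
- compound 2, `COc1cc(N/C=C\C(=O)c2cn(-c3ccccc3)nc2-c2ccc(Cl)cc2)cc(OC)c1OC`, 12700 nM in this assay
- compound 3, `COc1ccc(-c2nn(-c3ccccc3)cc2C(=O)/C=C\Nc2ccc(F)cc2)cc1`, 7650 nM in this assay

Compound 1 and compound 2 share one core and differ in a single place: chloro in place of fluoro on an aromatic carbon. The step of a 1.6-fold higher number from compound 1 to compound 2 (0.21 log units; within the scatter) is small and stays within the scatter, so the two numbers cannot be ordered against each other.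

Compound 3 is built on a different core. The difference between the core of compound 3 and the core of compound 1 is not broken down here. In this assay compound 3 gives 7650 nM, which lies within the scatter of compound 1 and also of compound 2; no order among the three is supported.

Compound 4, `COc1ccc(-c2nn(-c3ccccc3)cc2C(=O)/C=C\Nc2ccc(Cl)cc2)cc1`, is not yet measured. It differs from compound 3 in one place: chloro in place of fluoro on an aromatic carbon. The place is the same, word for word, as in the pair of compound 1 and compound 2, so this is the same change, now made on the core of compound 3. Within the data shown here, the only guide is the single earlier instance, where the step of a 1.6-fold higher number from compound 1 to compound 2 (0.21 log units; within the scatter) did not leave the scatter. The expectation is therefore a step of similar small size, a 1.3-fold higher number from compound 3 to compound 4 (0.12 log units; within the scatter), because the earlier step of a 1.6-fold higher number from compound 1 to compound 2 (0.21 log units; within the scatter) was of that size. Compound 4 is estimated at 10000 nM in this assay, with a range from 4000 nM to 25000 nM; this rests on a single precedent and is held loosely.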

Compound 4, half-maximal inhibitory concentration: 4760 nM
The estimate for compound 4 lay 2.1-fold (0.32 log units) above the measured number, within the range that was stated.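

Among these compounds, on the core of compound 3 in this assay, chloro in place of fluoro on an aromatic carbon gives a 1.6-fold lower number from compound 3 to compound 4 (0.21 log units; within the scatter), so this step cannot be told apart from no step at all. Set beside the same change on the core of compound 1, neither the two steps nor the gap between them leaves the scatter: the same change on two cores in this assay, a 1.6-fold higher number (0.21 log units; within the scatter) from compound 1 to compound 2 and a 1.6-fold lower number (0.21 log units; within the scatter) from compound 3 to compound 4, 2.6-fold (0.42 log units) apart, within the scatter of two such steps

These two pairs therefore show that the change stays within the scatter on both cores, but they do not show that its size carries over from one core to the other, that it has no effect, or that the core has no influence on it, and on the core of compound 3 the change reads (4-fluorophenyl)amino to (4-chlorophenyl)amino, a wider setting that is not shown to match the one in the pair of compound 1 and compound 2.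

Open, as far as these compounds go, is whether a group of another kind at this place, such as a nitrile, an amine or a carboxylic acid, would give a step beyond the scatter on either core. Also open is which single places in the difference between the two cores matter, as that difference is not broken down in the compounds shown.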